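The source may report more compounds than this note shows. Statements on the series, on what has been measured and on what is new or still open speak of the compounds shown alone.

Working notes on the series. Compound 1 `N#CC1=C(N)OC(c2c[nH]c3ccccc23)=C(C#N)C1c1ccc2ccccc2c1` is recorded in a functional assay, tested at 400 ug/mL (a lower number here means a weaker effect, a higher number a stronger effect of the compound at the concentration tested), as "not active" (no number reported), with no number behind that entry. Among the measured compounds shown here, compound 2 `CN(C)c1ccc(C2C(C#N)=C(N)OC(c3c[nH]c4ccccc34)=C2C#N)cc1` gives 26.7% in this assay and is thus the only compound in the set with a measured number, so compound 2 stands alone, with no measured step against which to set it. Compound 3 `N#CC1=C(N)OC(c2c[nH]c3ccccc23)=C(C#N)C1c1ccc(F)cc1` differs from compound 2 by the change (fluoro in place of dimethylamino on an aromatic carbon). For the measured compounds named here, no measured pair covers a change of this kind, so the direction rests on the single number of compound 2. A modest fall in this assay is expected, of a size near the scatter, and the estimated step is a number 10.7 percentage points lower from compound 2 to compound 3 (beyond the scatter). Compound 3 is estimated at 16% in this assay, with a range from 2% to 32%. The range is kept wide since only compound 2 with 26.7% supports the estimate.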

Compound 3, a percentage reported as activity, at one concentration (the size of the read-out at that concentration, not a potency): 26.7%
The estimate for compound 3 lay 10.7 percentage points below the measured number; measured number inside the range.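

Swapping 4-(dimethylamino)phenyl for 4-fluorophenyl, with the group on an aromatic carbon para to a large group, gives in this assay no change at the digits printed from compound 2 to compound 3 (within the scatter). This first measured step at this position shows that dimethylamino, with its 3 heavy atoms and 1 hydrogen-bond acceptor, and fluoro, with 1 heavy atom and no hydrogen-bond acceptor, are not told apart by this read-out at the single concentration tested. No supporting data bear on why the read-out holds across this change.

One pair at one concentration cannot show whether the two compounds would also match at other concentrations, and it sets no trend for the position. It also leaves open whether a carboxylic acid or a methoxy group on the same aromatic carbon would hold the read-out in this assay.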